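The source may report more compounds than this note shows. Statements on the series, on what has been measured and on what is new or still open speak of the compounds shown alone.

Compound 1 `Nc1ccccc1NC(=O)c1ccc(CNCc2nc(-c3ccc(C(F)(F)F)cc3)no2)cc1`: 19700 nM
Compound 2 `O=C(NO)c1ccc(CNCc2nc(-c3ccccc3)no2)cc1`: 29300 nM

In a functional assay on HCT-116 cells (Homo sapiens) for inhibition, read by MTT assay, with a stated time of 72 h (on this read-out lower numbers stand for stronger inhibition and higher numbers for weaker inhibition), compound 2 gives 29300 nM, which lies within the usual scatter of compound 1 at 19700 nM. For the measured compounds named here, these two numbers are all there is to go on, and no measured pair shows a single change in isolation. Compound 3 `O=C(NO)c1ccc(CNCc2nc(-c3ccc(C(F)(F)F)cc3)no2)cc1` differs from compound 2 in one place: trifluoromethyl in place of hydrogen on an aromatic carbon. With no measured guide to this change, no shift beyond the scatter is expected in this assay. The expected step of a 1.3-fold lower number from compound 2 to compound 3 (0.12 log units; within the scatter) is therefore small. Compound 3 is estimated at 22000 nM, with an expected range of 8000 nM to 60000 nM.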

Compound 3, half-maximal inhibitory concentration: 43100 nM
The estimate for compound 3 lay 2.0-fold (0.29 log units) below the measured number; the measured number falls inside the stated range.
By their numbers in this assay, from the lowest: compounds 1, 2 and 3 (each within the scatter of the next, the first and the last beyond it).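

In this assay, putting trifluoromethyl in place of hydrogen on the aromatic carbon gives a 1.5-fold higher number from compound 2 to compound 3 (0.17 log units; within the scatter), so this pair shows no shift beyond the scatter. For the compounds shown here, the other single change, hydroxy in place of 2-aminophenyl on an amide-type nitrogen, gives a 2.2-fold higher number from compound 1 to compound 3 (0.34 log units; beyond the scatter) and is the first step here beyond the scatter, though a modest one. Nothing at hand explains either step.

Going by these compounds, whether a chlorine atom, a methoxy group or an amine at that aromatic carbon would give a step beyond the scatter stays open. So does how the 2-aminophenyl compound would read with hydrogen in place of trifluoromethyl.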